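A few compounds are considered here, and "the series" means these few. Any claim that something is new, unique, unknown or untested is made for them only; others in the source may bear on it.

Compound 1 `CCCCC[Se]c1nc(N)c2ccccc2n1` in a functional assay on HT-29 cells (Homo sapiens) for cytotoxicity, read by MTT assay, with a stated time of 72 h (a higher number here means that more compound is tolerated, a lower number that less compound is tolerated), gives > 100000 nM, which is a limit of the assay.
Compound 2 `[SeH]c1nc([SeH])c2ccccc2n1` in this assay gives 87900 nM.

Going by the values given here, compound 2 holds the only number recorded; the result for compound 1 stands at a limit of the assay (the limit of > 100000 nM in this assay, at which 1 of the 2 values shown sits). Compound 3 `Nc1nc([SeH])nc2ccccc12` differs from compound 2 by one nitrogen atom in place of one selenium atom, on an aromatic carbon. Among the compounds with values here, no step between two measured compounds is available, so the direction rests on the structural change alone; in this assay a modest rise is expected, possibly beyond the scatter. Compound 3 is estimated at 150000 nM, with a range from 50000 nM to 400000 nM. The expected step is a 1.7-fold higher number from compound 2 to compound 3 (0.23 log units; within the scatter).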

Compound 3, concentration lethal to 50% of the cells: > 100000 nM
Compound 3 gave a limit, no number; the forecaster's own chance of this, stated with the estimate: 55%; the middle value lies beyond the limit too.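

In this assay amino in place of selenium on this aromatic carbon gives an at least 1.1-fold higher number from compound 2 to compound 3 (0.05 log units; that floor lies within the scatter) and so the change is bounded on one side only, with a floor that does not leave the scatter. Compound 3 stands at a limit of the assay, not at a number, and the series now holds more limits than numbers: the limit of > 100000 nM in this assay, at which 2 of the 3 values shown sit. The step between compound 1 and compound 3 cannot be read.

As far as these compounds go, how far compound 3 lies past its limit stays open. So does the outcome with a methyl or a hydroxyl on this aromatic carbon.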